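Chloro-to-trifluoromethyl swap on the amide aryl ring

The source may report more compounds than this note shows. Statements on the series, on what has been measured and on what is new or still open speak of the compounds shown alone.

Measured compounds in a functional assay on MDA-MB-435 cells (Homo sapiens) for antiproliferative activity, read by sulforhodamine B assay, with a stated time of 48 h; on this read-out lower numbers stand for stronger inhibition and higher numbers for weaker inhibition:
- compound 1 `COc1cc(-c2nn(-c3ccc(NC(=O)c4ccc(Cl)c(Cl)c4)cc3)cc2-c2ccncc2)ccc1Cl`: 7130 nM
- compound 2 `COc1cc(-c2nn(-c3ccc(NC(=O)c4ccc(Cl)c(C(F)(F)F)c4)cc3)cc2-c2ccncc2)ccc1Cl`: 2520 nM
- compound 3 `O=C(Nc1ccc(-n2cc(-c3ccncc3)c(-c3ccc(Cl)c(O)c3)n2)cc1)c1ccc(Cl)c(Cl)c1`: 2730 nM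

Compound 3 stands second highest of the three numbers. Its nearest neighbour is compound 2, and the gap between them is within the scatter; compound 1 is the furthest away, as the step of a 2.6-fold lower number from compound 1 to compound 3 (0.42 log units; beyond the scatter) shows, which is hydrogen in place of methyl on an oxygen on an aromatic ring.

Compound 4 `O=C(Nc1ccc(-n2cc(-c3ccncc3)c(-c3ccc(Cl)c(O)c3)n2)cc1)c1ccc(Cl)c(C(F)(F)F)c1` differs from compound 3 by trifluoromethyl in place of chloro on an aromatic carbon. For the measured compounds named here, the one measured step bearing directly on this change is a 2.8-fold lower number from compound 1 to compound 2 (0.45 log units; beyond the scatter), which is the same swap of trifluoromethyl for chloro on the same aromatic carbon of the amide aryl ring, carried out on the methoxy rather than the hydroxy core. That step was modest but beyond the scatter. A step of about the same size and in the same direction, a lower number, is therefore expected here, with the caution that it rests on a single precedent.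

On that basis compound 4 is estimated at 1000 nM, within 400 nM to 2500 nM, the expected step being a 2.7-fold lower number from compound 3 to compound 4 (0.44 log units; beyond the scatter).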

Compound 4, half-maximal inhibitory concentration: 1200 nM
Compound 4: the middle estimate sits 1.2-fold (0.08 log units) below what was measured; measured number inside the range.
By their numbers in this assay, from the lowest: compound 4; then compounds 2 and 3 (each within the scatter of the next); then compound 1.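

In this assay, the change from 3,4-dichlorophenyl to 4-chloro-3-(trifluoromethyl)phenyl now holds on a second core, with a 2.3-fold lower number from compound 3 to compound 4 (0.36 log units; beyond the scatter), so the effect at this aromatic carbon no longer rests on a single pair, and the two readings agree: the same change on two cores in this assay, a 2.8-fold lower number (0.45 log units; beyond the scatter) from compound 1 to compound 2 and a 2.3-fold lower number (0.36 log units; beyond the scatter) from compound 3 to compound 4, 1.2-fold (0.09 log units) apart, within the scatter of two such steps

Hydrogen in place of methyl on the oxygen also repeats once the trifluoromethyl group is present, with a 2.1-fold lower number from compound 2 to compound 4 (0.32 log units; beyond the scatter), and again the two readings agree: the same change on two cores in this assay, a 2.6-fold lower number (0.42 log units; beyond the scatter) from compound 1 to compound 3 and a 2.1-fold lower number (0.32 log units; beyond the scatter) from compound 2 to compound 4, 1.2-fold (0.09 log units) apart, within the scatter of two such steps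

For the compounds shown here, each change therefore keeps about the same size whichever form the other place takes, so across these four compounds the two changes behave as independent of each other, and no compound goes against this.

The compounds shown leave open whether a nitrile or a bromo group on this aromatic carbon would lower the number further than trifluoromethyl does, and whether a longer chain on the oxygen would read closer to the methyl or to the hydrogen. Going by these compounds, all four readings also come from one cell line, so whether these steps carry over to other cells remains open.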